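From Ethynyl to a Chlorophenyl Triazole

The source may hold more compounds than are shown below. What is called first, only, known or untested is meant among the compounds shown, and "the series" means these compounds.

Results in a functional assay on DU-145 cells (Homo sapiens) for antiproliferative activity, read by MTT assay, with a stated time of 48 h (on this read-out lower numbers stand for stronger inhibition and higher numbers for weaker inhibition), for the two measured compounds:
compound 1 `C/C(=C\CC/C(C)=C/CC[C@@H]1[C@@]2(C)CCC(=O)C(C)(C)[C@H]2CC[C@@]1(C)O)CC/C=C(\C)C(=O)OCc1cn(-c2ccccc2C(F)(F)F)nn1` gives > 150000 nM (a limit, not a number)
compound 2 `C#CCOC(=O)/C(C)=C/CC/C(C)=C/CC/C(C)=C/CC[C@@H]1[C@@]2(C)CCC(=O)C(C)(C)[C@H]2CC[C@@]1(C)O` gives 46100 nM (a number)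

Going by the values given here, compound 2 holds the only true number so far, since the entry for compound 1 is a limit. Compound 3 `C/C(=C\CC/C(C)=C/CC[C@@H]1[C@@]2(C)CCC(=O)C(C)(C)[C@H]2CC[C@@]1(C)O)CC/C=C(\C)C(=O)OCc1cn(-c2cccc(Cl)c2)nn1` shares its core with compound 2 and differs in one place: 1-(3-chlorophenyl)-1H-1,2,3-triazol-4-yl in place of ethynyl on a saturated chain carbon bound to an oxygen next to a carbonyl group. Among the compounds with values here, no measured pair isolates this change. Within the data shown here, the only guide is compound 1, which carries a related triazole group in the same place and whose entry > 150000 nM is a limit. A small weakening, close to the usual scatter, is therefore expected (a 1.8-fold higher number from compound 2 to compound 3 (0.27 log units; within the scatter)). Compound 3 is estimated at 85000 nM within an expected range of 35000 nM to 150000 nM in repeated measurements.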

Compound 3, half-maximal inhibitory concentration: 103000 nM
The estimate for compound 3 lay 1.2-fold (0.08 log units) below the measured number; the range from low to high includes it.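

Swapping ethynyl for 1-(3-chlorophenyl)-1H-1,2,3-triazol-4-yl on a saturated chain carbon bound to an oxygen next to a carbonyl group gives the first true number for a triazole at this place, and the change is modest: a 2.2-fold higher number from compound 2 to compound 3 (0.35 log units; beyond the scatter). The entry for compound 1 is a limit, not a number: the limit of > 150000 nM in this assay, at which 1 of the 3 values shown sits. Placing 3-chlorophenyl instead of 2-(trifluoromethyl)phenyl on an aromatic nitrogen gives an at least 1.4-fold lower number from compound 1 to compound 3 (0.16 log units; that floor lies within the scatter), so these two aryl groups cannot be ranked.

Going by these compounds, it remains open whether the modest step comes from the triazole ring or from the aryl group it carries. A triazole bearing a plain phenyl, or a phenyl carrying an amine or a carboxylic acid, would help to separate the two.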